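Urea to Phenylethylamine on a Shared Tryptamine-Piperidine Core

The source may hold more compounds than are shown below. What is called first, only, known or untested is meant among the compounds shown, and "the series" means these compounds.

Measured so far:
compound 1 `O=S(=O)(NCC1CCN(CCCc2c[nH]c3ccc(-n4cnnc4)cc23)CC1)c1ccccc1`, in an assay on CHO cells for displacement of a labelled ligand from 5-hydroxytryptamine receptor 1B (Homo sapiens) (on this read-out higher numbers stand for weaker inhibition and lower numbers for stronger inhibition), compound 1 gives 60 nM
compound 2 `CN(CC1CCN(CCCc2c[nH]c3ccc(-n4cnnc4)cc23)CC1)C(=O)Nc1ccccc1`, in this assay compound 2 gives 6.2 nM

Within the data shown here, compound 2 stands lowest of the two numbers seen in this assay; its nearest neighbour is compound 1, and the only step so far, a 9.7-fold lower number from compound 1 to compound 2 (0.99 log units; beyond the scatter), shows how far apart they lie.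

Compound 3 `C[C@@H](NCC1CCN(CCCc2c[nH]c3ccc(-n4cnnc4)cc23)CC1)c1ccccc1` differs from compound 2 in one place: (1-phenylethyl)amino in place of methyl(phenylcarbamoyl)amino on a saturated chain carbon bound to a saturated ring carbon. Among the measured compounds shown here, no measured step covers this particular exchange. For the measured compounds named here, the single step of a 9.7-fold lower number from compound 1 to compound 2 (0.99 log units; beyond the scatter) bears on it only loosely, since it shows that the group at this position can shift the number by a modest amount in either direction. Compound 3 is therefore expected to land near compound 2, with a step of a 2.4-fold higher number from compound 2 to compound 3 (0.38 log units; beyond the scatter) in this assay that may not exceed the scatter. The estimate for compound 3 in this assay is 15 nM, within 4 nM to 60 nM.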

Compound 3, half-maximal inhibitory concentration: 14 nM
Beside the measured number, compound 3's estimate is 1.1-fold (0.03 log units) above it, within the range that was stated.
By their numbers in this assay, from the lowest: compound 2; then compound 3; then compound 1.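

The position tolerates a group with no oxygen and no carbonyl: (1-phenylethyl)amino in place of methyl(phenylcarbamoyl)amino gives a 2.3-fold higher number from compound 2 to compound 3 (0.35 log units; beyond the scatter) in this assay, a modest loss that leaves compound 3 much closer to compound 2 than to compound 1. On the same amine nitrogen, 1-phenylethyl in place of phenylsulfonyl gives a 4.3-fold lower number from compound 1 to compound 3 (0.63 log units; beyond the scatter) and so places compound 3 between the urea and the sulfonamide, with compound 1 highest of the three. Nothing available explains the order of these three groups.

The compounds shown carry only one defined stereocentre at this position, so they leave open what the opposite configuration of the 1-phenylethyl group would give. They also leave open whether a plain benzyl group, without the methyl, or a longer 2-phenylethyl chain would give a number nearer that of compound 2.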